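A few compounds are considered here, and "the series" means these few. Any claim that something is new, unique, unknown or untested is made for them only; others in the source may bear on it.

Values in a functional assay for antagonist activity at P2X purinoceptor 7 (Homo sapiens); on this read-out higher numbers stand for weaker inhibition and lower numbers for stronger inhibition: compound 1 `CCc1n[nH]c(CC)c1CCC(=O)NCc1ccc(F)cc1Cl` gives 10 nM; compound 2 `CC(C)c1n[nH]c(C(C)C)c1CCC(=O)NCc1ccc(F)cc1Cl` gives 126 nM; compound 3 `Cc1n[nH]c(CC(C)C)c1CCC(=O)NCc1ccc(F)cc1Cl` gives 100 nM.

Compound 3 holds the second highest of the three numbers. Its nearest neighbour is compound 2, whose number is only slightly higher, a gap within the usual scatter, so no order between compound 2 and compound 3 can be read from these two values. For the measured compounds named here, the furthest is compound 1, whose number is lower by a margin well beyond the scatter; the two values show compound 1 as the clearly stronger inhibitor of the pair, though no single-point step between compound 1 and compound 3 is available.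

Compound 4 `Cc1n[nH]c(-c2ccccc2)c1CCC(=O)NCc1ccc(F)cc1Cl` is the next member. It differs from compound 3 in one place: phenyl in place of isobutyl on an aromatic carbon. Going by the values given here, no pair of measured compounds differing in one place exists, so the size of this step has no direct precedent. Among the compounds with values here, the only hint is that compound 1 and compound 2, which carry smaller and larger alkyl groups on the same core, differ by a step beyond the scatter with the larger groups giving the higher number; phenyl brings more heavy atoms than isobutyl. A modest rise, or no change beyond the scatter, is expected: a 1.6-fold higher number from compound 3 to compound 4 (0.20 log units; within the scatter). Compound 4 is estimated at 160 nM, within a range of 40 nM to 650 nM.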

Compound 4, half-maximal inhibitory concentration: > 1000 nM
Compound 4 ended at the assay's limit; the forecaster's own chance of this, stated with the estimate: 5%; middle value at least 6.2-fold (0.79 log units) from the limit.
By their numbers in this assay, from the lowest: compound 1; then compounds 3 and 2 (each within the scatter of the next). At a limit, above all of these: compound 4.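

In this assay compound 4 gives > 1000 nM, which is a limit of the assay and not a number: the limit of > 1000 nM in this assay, at which 1 of the 4 values shown sits.

Phenyl in place of isobutyl on this aromatic carbon gives an at least 10-fold higher number from compound 3 to compound 4 (1.00 log units; beyond the scatter), the first step in the series read from a change in one place, and it shows that the read-out is sensitive to the group at this position. The earlier compounds shown here carried only open alkyl groups on the shared core, so this is also the first sign that a six-membered aromatic ring of carbon only at this position is accompanied by a clear loss of inhibition, with the full size of the step hidden by the limit.

The compounds shown do not separate the effect of the aromatic ring from that of the added heavy atoms, and a cyclohexyl or benzyl group at this carbon would bear directly on that question. On these data alone, it also remains open whether a pyridyl ring, or a phenyl ring carrying an amine or a carboxylic acid, would give a number that can be read below the limit.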